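Working notes: from compound 2 to compound 3

This account rests on a few compounds, and the source may have more. Where it says the series, first, only, none or still open, it means among the compounds named here.

Compound 1 `COc1cc2ncnc(Nc3ccc(NC(=O)c4ccccc4OC)cc3)c2cc1OC`: > 100000 nM (a limit)
Compound 2 `COc1cc2ncnc(Nc3ccc(NC(=O)c4ccc(I)cc4)cc3)c2cc1OC`: 40000 nM

Within the data shown here, in a functional assay on HepG2 cells (Homo sapiens) for inhibition, read by MTT assay (on this read-out higher numbers stand for weaker inhibition and lower numbers for stronger inhibition), compound 2, at 40000 nM, holds the only actual number so far. Compound 1 stands at a limit, > 100000 nM.

The next structure is compound 3 `COc1cc2ncnc(Nc3ccc(NC(=O)c4ccc(Cl)c(Cl)c4)cc3)c2cc1OC`, with this change: 3,4-dichlorophenyl in place of 4-iodophenyl on a carbonyl carbon. Among the measured compounds shown here, one measured step bears on it: an at least 2.5-fold lower number from compound 1 to compound 2 (0.39 log units; beyond the scatter). That step touched the same place, on a carbonyl carbon, and was at least modest. For the measured compounds named here, one end of it is a limit, so its full size is unknown, and no measured compound carries 3,4-dichlorophenyl. As far as these compounds go, no step beyond the scatter is therefore expected in this assay, and either direction remains open. The expected step is a 1.1-fold lower number from compound 2 to compound 3 (0.06 log units; within the scatter). For compound 3 the estimated value is 35000 nM, with an expected range of 14000 nM to 90000 nM.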

Compound 3, half-maximal inhibitory concentration: 28000 nM
The estimate for compound 3 lay 1.3-fold (0.10 log units) above the measured number, within the range that was stated.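

In this assay, 3,4-dichlorophenyl in place of 4-iodophenyl on a carbonyl carbon gives a 1.4-fold lower number from compound 2 to compound 3 (0.15 log units; within the scatter), so this position does not separate these two groups. With 2-methoxyphenyl replaced at the same place, the result is an at least 3.5-fold lower number from compound 1 to compound 3 (0.55 log units; beyond the scatter), which gives a second halogen-bearing ring that reads beyond the scatter from the 2-methoxyphenyl compound. The full size of that step remains unknown because compound 1 stands at a limit: the limit of > 100000 nM in this assay, at which 1 of the 3 values shown sits.

The compounds shown do not separate any contribution of losing the methoxy group from that of gaining chlorine or iodine. As far as these compounds go, how an unsubstituted phenyl, an aminophenyl or a carboxyphenyl on the same carbonyl carbon would read in this assay also stays open.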